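Aryl replacement at the fused core: compound 2 toward compound 4

A few compounds are considered here, and "the series" means these few. Any claim that something is new, unique, unknown or untested is made for them only; others in the source may bear on it.

Three compounds share one core and differ only in the aryl group on it. Compound 1 `CCCS(=O)(=O)Nc1ccc(F)c(C(=O)c2n[nH]c3ncc(-c4ccccc4Cl)cc23)c1F` gives 9.3% in an assay for binding affinity to dual specificity mitogen-activated protein kinase kinase 4 (Homo sapiens), read by KINOMEscan, tested at 100 nM; on this read-out lower numbers stand for a stronger effect and higher numbers for a weaker effect at the one concentration tested. Compound 2 `CCCS(=O)(=O)Nc1ccc(F)c(C(=O)c2n[nH]c3ncc(-c4ccccc4OC)cc23)c1F` gives 1.9% in this assay, and compound 3 `CCCS(=O)(=O)Nc1ccc(F)c(C(=O)c2n[nH]c3ncc(-c4cccc(OC)c4)cc23)c1F` gives 6.3%. Compound 2 sits at the low end of the three numbers, but the steps of a number 4.4 percentage points higher from compound 2 to compound 3 (within the scatter) and a number 7.4 percentage points lower from compound 1 to compound 2 (within the scatter) are both within the scatter, as is a number 3 percentage points lower from compound 1 to compound 3 (within the scatter), so the three compounds cannot be separated on these data.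

Compound 4 `CCCS(=O)(=O)Nc1ccc(F)c(C(=O)c2n[nH]c3ncc(-c4cc(Cl)cc(Cl)c4)cc23)c1F` is unmeasured. Relative to compound 2 the change is 3,5-dichlorophenyl in place of 2-methoxyphenyl on an aromatic carbon. For the measured compounds named here, the steps that bear on it are the chloro-for-methoxy exchange, a number 7.4 percentage points lower from compound 1 to compound 2 (within the scatter), and the shift of the methoxy between ring positions, a number 4.4 percentage points higher from compound 2 to compound 3 (within the scatter); neither moved the read-out beyond the scatter. A change in this assay of no more than the scatter is therefore expected, with a number 4.1 percentage points higher from compound 2 to compound 4 (within the scatter) as the estimated step. Compound 4 is expected to give 6%, within 1% to 20%.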

Compound 4, a percentage reported as activity, at one concentration (the size of the read-out at that concentration, not a potency): 73%
Beside the measured number, compound 4's estimate is 67 percentage points below it; measured number outside the range, above it.
By their numbers in this assay, from the lowest: compounds 2, 3 and 1 (each within the scatter of the next); then compound 4.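

The aryl position on the shared core does not treat every aryl group alike in this assay: 3,5-dichlorophenyl separates from all three earlier groups, with each step beyond the scatter (a number 71.1 percentage points higher from compound 2 to compound 4 (beyond the scatter)) (a number 66.7 percentage points higher from compound 3 to compound 4 (beyond the scatter)) (a number 63.7 percentage points higher from compound 1 to compound 4 (beyond the scatter)). The 2-chlorophenyl of compound 1 stays within the scatter of both methoxyphenyl compounds, so one chlorine on this ring does not by itself give the high number of compound 4. Nothing measured in this set accounts for the size of these steps.

The compounds shown leave open whether the large rise follows from having two chlorines or from where they sit on the ring. A 3-chlorophenyl or a 3,5-dimethoxyphenyl at this position would help separate those two readings.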